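A fluorophenyl replaces the methylpyridinyl: expected potency

The source may hold more compounds than are shown below. What is called first, only, known or untested is meant among the compounds shown, and "the series" means these compounds.

Three compounds share one core and differ only in the group joined through the oxygen on the aromatic ring. Compound 1 `O=C1NC(=O)C(Cc2ccc(OCc3ccccc3)cc2)S1` carries a benzyl there, and in a functional assay for agonist activity at Free fatty acid receptor 1 (Homo sapiens), read by FLIPR, in the presence of a further agent that is not named here (a lower number here means that less compound is needed, a higher number that more compound is needed for the effect), compound 1 gives 6180 nM. Compound 2 `Cc1cccc(Oc2ccc(CC3SC(=O)NC3=O)cc2)n1` carries a 6-methylpyridin-2-yl, and in this assay compound 2 gives 2620 nM. Compound 3 `Cc1cccnc1Oc1ccc(CC2SC(=O)NC2=O)cc1` carries a 3-methylpyridin-2-yl, and in this assay compound 3 gives 1090 nM, the lowest of the three numbers: a 5.7-fold lower number from compound 1 to compound 3 (0.75 log units; beyond the scatter), and a 2.4-fold lower number from compound 2 to compound 3 (0.38 log units; beyond the scatter). Compound 4 `O=C1NC(=O)C(Cc2ccc(Oc3ccc(F)cc3)cc2)S1` is not yet measured; it differs from compound 3 in one place: 4-fluorophenyl in place of 3-methylpyridin-2-yl on an oxygen on an aromatic ring. Going by the values given here, no measured step tests this exact exchange. The steps that come nearest are a 2.4-fold lower number from compound 1 to compound 2 (0.37 log units; beyond the scatter) and a 5.7-fold lower number from compound 1 to compound 3 (0.75 log units; beyond the scatter), both exchanges of the group on that same oxygen, and both modest. Among the compounds with values here, a modest step is therefore expected here as well, most likely toward a higher number, as compound 1, the only compound without a methylpyridinyl group, gives 6180 nM. Compound 4 is expected to give 2200 nM in this assay, within 800 nM to 6000 nM, meaning a 2.0-fold higher number from compound 3 to compound 4 (0.30 log units; within the scatter).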

Compound 4, half-maximal effective concentration: 480 nM
Estimate against measurement, compound 4: 4.6-fold (0.66 log units) above; the measured number lies below the stated range.
By their numbers in this assay, from the lowest: compound 4; then compound 3; then compound 2; then compound 1.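

In this assay this position does not need a methylpyridinyl group: a 4-fluorophenyl, with carbon only in its ring, gives a 2.3-fold lower number from compound 3 to compound 4 (0.36 log units; beyond the scatter) and also a 5.5-fold lower number from compound 2 to compound 4 (0.74 log units; beyond the scatter), so a ring nitrogen is not required for the lowest number among these four compounds. Going by these compounds alone, the widest gap at this position is now a 13-fold lower number from compound 1 to compound 4 (1.11 log units; beyond the scatter), the first step here large rather than modest, with 4-fluorophenyl in place of benzyl. No measurement shown accounts for the advantage of the 4-fluorophenyl group.

Compound 4 changes the ring atoms and adds fluorine in one exchange, so the part played by the fluorine stays unclear. A plain phenyl on this oxygen would separate the two, and a 4-chlorophenyl or 4-methoxyphenyl would show whether fluorine can be replaced.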